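A few compounds are considered here, and "the series" means these few. Any claim that something is new, unique, unknown or untested is made for them only; others in the source may bear on it.

Values in a functional assay on HCT-116 cells (Homo sapiens) for antiproliferative activity, read by MTT assay, with a stated time of 48 h (on this read-out lower numbers stand for stronger inhibition and higher numbers for weaker inhibition), for the measured compounds:

compound 1, `CCCCCC(CCO)n1cnc2c(Cl)nc(F)nc21`: 8660 nM
compound 2, `CCCCCC(CCO)n1cnc2c(Cl)ncnc21`: > 50000 nM
compound 3, `CCCCCCC(CCO)n1cnc2c(Cl)nc(F)nc21`: 9960 nM

The entry for compound 2 is a limit of the assay and not a number (the limit of > 50000 nM in this assay, at which 1 of the 3 values shown sits).

The pair compound 1 to compound 2 is the change (hydrogen in place of fluoro on an aromatic carbon). It gave an at least 5.7-fold higher number from compound 1 to compound 2 (0.76 log units; beyond the scatter).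

Compound 1 and compound 3 differ by methyl in place of hydrogen on a saturated chain carbon, six bonds along the chain from an aromatic nitrogen, and in this assay a 1.2-fold higher number from compound 1 to compound 3 (0.06 log units; within the scatter), so the two fluoro-bearing cores sit together.

Compound 4, `CCCCCCC(CCO)n1cnc2c(Cl)ncnc21`, is not yet measured. It differs from compound 3 by hydrogen in place of fluoro on an aromatic carbon. This is the same change as from compound 1 to compound 2: the place described around it is the same word for word, and the rest of the two cores differs only by the methyl on the chain already told. Given that the earlier step was an at least 5.7-fold higher number from compound 1 to compound 2 (0.76 log units; beyond the scatter) and that compound 3 starts from 9960 nM, the step from compound 3 to compound 4 is expected to be a 6.5-fold higher number from compound 3 to compound 4 (0.81 log units; beyond the scatter).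

Compound 4 is therefore estimated at 65000 nM, within 25000 nM to 200000 nM.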

Compound 4, half-maximal inhibitory concentration: 11900 nM
The estimate for compound 4 lay 5.5-fold (0.74 log units) above the measured number; the measured number lies below the stated range.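

In this assay, hydrogen in place of fluoro on an aromatic carbon gave a 1.2-fold higher number from compound 3 to compound 4 (0.08 log units; within the scatter), so the large step seen on the shorter-chain core did not carry over to the core of compound 3: the same change on two cores in this assay, an at least 5.7-fold higher number (0.76 log units; beyond the scatter) from compound 1 to compound 2 and a 1.2-fold higher number (0.08 log units; within the scatter) from compound 3 to compound 4, at least 4.8-fold (0.68 log units) apart, beyond the scatter of two such steps

Read the other way, the methyl on the chain gave an at least 4.2-fold lower number from compound 2 to compound 4 (0.62 log units; beyond the scatter), although the same methyl left the two fluoro-bearing compounds within the scatter of each other: the same change on two cores in this assay, a 1.2-fold higher number (0.06 log units; within the scatter) from compound 1 to compound 3 and an at least 4.2-fold lower number (0.62 log units; beyond the scatter) from compound 2 to compound 4, at least 4.8-fold (0.68 log units) apart, beyond the scatter of two such steps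

Within the data shown here, the entry for compound 2 is a limit and not a number, and these four compounds show only that neither step can be assumed to transfer between the two cores, not why the steps part or how they would behave on any other core.

Going by these compounds, it remains open whether an amine on the aromatic carbon between two ring nitrogen atoms would follow the fluoro compounds or the hydrogen compounds. A longer chain, or a carboxylic acid at the end of the chain, would test whether the dependence of the fluoro step on the chain persists.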